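The source may report more compounds than this note shows. Statements on the series, on what has been measured and on what is new or still open speak of the compounds shown alone.

Compound 1 `C=C(CC)C(=O)c1ccc(OCC(=O)NCCCN2CCCC2=O)c(Cl)c1Cl`: 13800 nM
Compound 2 `C=C(CC)C(=O)c1ccc(OCC(=O)Nc2nc3ccccc3s2)c(Cl)c1Cl`: 1500 nM
Compound 3 `C=C(CC)C(=O)c1ccc(OCC(=O)Nc2ccc(C(=O)O)cc2)c(Cl)c1Cl`: 5000 nM

In a functional assay on CLL cells (Homo sapiens) for cytotoxicity, read by MTT assay, with a stated time of 48 h (on this read-out higher numbers stand for an effect only at larger amounts of compound and lower numbers for an effect already at smaller amounts), compound 3 holds the second highest of the three numbers. Compound 4 `C=C(CC)C(=O)c1ccc(OCC(=O)Nc2ccc(S(=O)(=O)O)cc2)c(Cl)c1Cl` departs from it at one place, sulfo in place of carboxy on an aromatic carbon. Within the data shown here, no measured step makes this exchange. The nearest evidence comes from swaps of the whole group on the amide-type nitrogen: a 2.8-fold lower number from compound 1 to compound 3 (0.44 log units; beyond the scatter) and a 3.3-fold higher number from compound 2 to compound 3 (0.52 log units; beyond the scatter). Both are modest and they run in opposite directions, so they give no direction for compound 4. The exchange here is smaller than those swaps, so no step beyond the scatter is expected. The estimated change is a 1.3-fold higher number from compound 3 to compound 4 (0.11 log units; within the scatter) in this read-out. Compound 4 is estimated at 6500 nM (expected range 2500 nM to 20000 nM).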

Compound 4, half-maximal effective concentration: > 25000 nM
Compound 4: no number, only a limit; the forecaster's own chance of this, stated with the estimate: 8%; middle value at least 3.8-fold (0.58 log units) away from the limit.
By their numbers in this assay, from the lowest: compound 2; then compound 3; then compound 1. At a limit, above all of these: compound 4.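

In this assay, among these compounds, the earlier compounds varied only the whole group on the amide-type nitrogen, whereas here a single exchange on an aromatic carbon, para to a large group, gives an at least 5.0-fold higher number from compound 3 to compound 4 (0.69 log units; beyond the scatter). At this place, sulfo does not keep the value seen with carboxy. Compound 4 has no number, only a limit of the assay: the limit of > 25000 nM in this assay, at which 1 of the 4 values shown sits.

The compounds shown leave open how an amine, a methyl ester or a primary amide would behave at this same place on the ring.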